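A few compounds are considered here, and "the series" means these few. Any claim that something is new, unique, unknown or untested is made for them only; others in the source may bear on it.

Measured so far in a functional assay with Mus musculus as the target; on this read-out higher numbers stand for an effect only at larger amounts of compound and lower numbers for an effect already at smaller amounts:
compound 1, `Nc1nc(O)c2c(n1)n(C1OC(CO)[C@@H](O)[C@H]1O)c(=O)n2C/C=C/c1ccccc1`: 4 uM
compound 3, `C=CCn1c(=O)n(CCCC)c2nc(N)nc(O)c21`: 11 uM
compound 2, `CCCn1c(=O)n(C2CCC(COC(C)=O)O2)c2nc(NC(C)=O)nc(O)c21`: 80 uM

Of these three numbers, compound 1 gives the lowest, 4 uM. Compound 3, with its smaller groups on the shared core, gives 11 uM, a higher number that lies beyond the usual scatter. Compound 2 gives 80 uM, the highest of the three, also well beyond the scatter. Compound 4, `Cn1c(=O)n(C2OC(CO)[C@@H](O)[C@H]2O)c2nc(N)nc(O)c21`, has not yet been measured. It differs from compound 1 in one place: hydrogen in place of 2-phenylethenyl on a saturated chain carbon bound to an aromatic nitrogen. Among the compounds with values here, no two measured compounds differ in only one place, so no single measured step shows what this change alone does. Both measured compounds that carry smaller groups than compound 1 give higher numbers, although each of them also differs from compound 1 elsewhere. A step towards a higher number, estimated as a 5.0-fold higher number from compound 1 to compound 4 (0.70 log units; beyond the scatter), is expected from compound 1 to compound 4, because compound 3 with smaller groups already gives 11 uM. Compound 4 is therefore expected to give about 20 uM, likely between 5 uM and 80 uM.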

Compound 4, concentration for half-maximal effect: 120 uM
Estimate against measurement, compound 4: 6.0-fold (0.78 log units) below; the whole stated range lies below it.
By their numbers in this assay, from the lowest: compound 1; then compound 3; then compounds 2 and 4 (each within the scatter of the next).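

In this assay the change from 3-phenylprop-2-en-1-yl to methyl, with everything else in the structure held the same, gives a 30-fold higher number from compound 1 to compound 4 (1.48 log units; beyond the scatter) and is a large step beyond the usual scatter. The earlier compounds shown here each differed from compound 1 in more than one place, whereas this pair shows that this position alone can shift the number strongly and that the low number of compound 1 depends on the 2-phenylethenyl group. Nothing measured here explains why this group matters so much.

From the compounds shown here alone, it remains open whether the step comes from the aromatic ring, the double bond or the chain length, as neither a saturated 3-phenylpropyl group nor a benzyl group appears here. Also open, going by these compounds, is how an amine or a carboxylic acid at the end of this chain would compare.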